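From piperazin-1-yl to fluoro in a flat series

The source may hold more compounds than are shown below. What is called first, only, known or untested is meant among the compounds shown, and "the series" means these compounds.

In an ADME assay on MCF7-DOX cells (Homo sapiens) for cytotoxicity, read by MTT assay, with a stated time of 48 h (on this read-out lower numbers stand for stronger inhibition and higher numbers for weaker inhibition), compound 1 (`COc1cc(OC)c(C(=O)/C=C/c2cccc(Cl)c2)c(O)c1CC=C(C)C`) gives 59500 nM while compound 2 (`COc1ccc(/C=C/C(=O)c2c(OC)cc(OC)c(CC=C(C)C)c2O)cc1`) gives 46900 nM and compound 3 (`COc1cc(OC)c(C(=O)/C=C/c2ccc(N3CCNCC3)cc2)c(O)c1CC=C(C)C`) gives 57800 nM on the same read-out, so compound 3 cannot be told apart from the other two. Compound 4 (`COc1cc(OC)c(C(=O)/C=C/c2ccc(F)cc2)c(O)c1CC=C(C)C`) has fluoro in place of piperazin-1-yl on an aromatic carbon, para to a large group (fluoro in place of piperazin-1-yl on an aromatic carbon). Two measured steps changed groups on that same aromatic ring (a 1.3-fold lower number from compound 1 to compound 2 (0.10 log units; within the scatter)) and (a 1.2-fold higher number from compound 2 to compound 3 (0.09 log units; within the scatter)), and both stayed within the scatter. In this assay a step within the scatter is therefore expected (a 1.2-fold lower number from compound 3 to compound 4 (0.06 log units; within the scatter)). For compound 4 the estimated value is 50000 nM (expected range 25000 nM to 90000 nM).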

Compound 4, half-maximal inhibitory concentration: 53700 nM
Estimate against measurement, compound 4: 1.1-fold (0.03 log units) below; low and high end bracket the measured number.
By their numbers in this assay, from the lowest: compounds 2, 4, 3 and 1 (each within the scatter of the next).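

In this assay, a single fluorine atom on this aromatic carbon, para to a large group, takes the place of piperazin-1-yl with its 6 heavy atoms and its ring, and the result is a 1.1-fold lower number from compound 3 to compound 4 (0.03 log units; within the scatter). Fluoro in place of methoxy gives a 1.1-fold higher number from compound 2 to compound 4 (0.06 log units; within the scatter), and 4-fluorophenyl in place of 3-chlorophenyl gives a 1.1-fold lower number from compound 1 to compound 4 (0.04 log units; within the scatter), so across these four compounds neither the size of the group nor the presence of a ring separates the values.

As far as these compounds go, whether a carboxylic acid or a longer chain on this aromatic carbon would go beyond the scatter remains open. Nothing at hand explains why these values stay together.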